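This account rests on a few compounds, and the source may have more. Where it says the series, first, only, none or still open, it means among the compounds named here.

Three compounds share one core and differ only in the group attached to the carbonyl carbon of the side chain. Compound 1 `Cc1cc(C#N)cc(C)c1Oc1nc(Nc2ccc(C#N)cc2)ncc1/C=C/C(=O)NCCOCCO` carries a (2-(2-hydroxyethoxy)ethyl)amino group there. In an ADME assay on TZM cells (Homo sapiens) for cytotoxicity, with a stated time of 1 days (a lower number here means that less compound is tolerated, a higher number that more compound is tolerated), compound 1 gives only a limit, > 200 nM, and no number. Compound 2 `Cc1cc(C#N)cc(C)c1Oc1nc(Nc2ccc(C#N)cc2)ncc1/C=C/C(=O)NCC1CCN(S(C)(=O)=O)C1` carries a ((1-(methylsulfonyl)pyrrolidin-3-yl)methyl)amino group; in this assay compound 2 likewise gives only a limit, > 175 nM. Compound 3 `CC(=O)N1CCN(C(=O)/C=C/c2cnc(Nc3ccc(C#N)cc3)nc2Oc2c(C)cc(C#N)cc2C)CC1` carries a 4-acetylpiperazin-1-yl group; in this assay compound 3 gives only a limit, > 192 nM. Compound 3 therefore stands among three compounds for which nothing but limits is known, and the steps a step that the two limits leave unreadable from compound 1 to compound 2, a step that the two limits leave unreadable from compound 1 to compound 3 and a step that the two limits leave unreadable from compound 2 to compound 3 stay unreadable because every end sits at a limit (the limit of > 175 nM in this assay, at which 1 of the 3 values shown sits, (the limit of > 192 nM in this assay, at which 1 of the 3 values shown sits), (the limit of > 200 nM in this assay, at which 1 of the 3 values shown sits)).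

Compound 4 `Cc1cc(C#N)cc(C)c1Oc1nc(Nc2ccc(C#N)cc2)ncc1/C=C/C(=O)N1CCN(C=O)CC1` differs from compound 3 by hydrogen in place of methyl on a carbonyl carbon. Within the data shown here, none of the measured steps touches this position, and none has a readable size, so no step beyond the scatter is expected; the step from compound 3 to compound 4 is estimated as a step that the limit leaves unreadable from compound 3 to compound 4. Compound 4 is expected to give 250 nM, in the range 150 nM to 600 nM, most likely again reported only as a limit.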

Compound 4, half-maximal cytotoxic concentration: > 197 nM
Compound 4 gave a limit, no number; the forecaster's own chance of this, stated with the estimate: 85%; the middle value does not contradict the limit.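

In this assay compound 4 gives only a limit, > 197 nM. Among these compounds, no step from compound 1, compound 2 or compound 3 to compound 4 can be read. The compounds shown leave open the concentration at which any of the four harms these cells, and whether acetyl to formyl changes it.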